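A 4-methylphenyl group replaces 2-chlorophenyl on the shared core

The source may report more compounds than this note shows. Statements on the series, on what has been measured and on what is new or still open speak of the compounds shown alone.

Of the compounds shown here, three that differ only in their chlorophenyl group have been read in a physicochemical assay for solubility, read by HPLC, in phosphate buffer, measured as kinetic solubility, at pH 7.4; a higher number here means a more soluble compound, a lower number a less soluble compound. Compound 1 `CCOC(=O)c1cc(-c2ccc(Cl)cc2)n(-c2ccc(S(N)(=O)=O)cc2)c1C`, with 4-chlorophenyl, gives 4200 nM. Compound 2 `CCOC(=O)c1cc(-c2cccc(Cl)c2)n(-c2ccc(S(N)(=O)=O)cc2)c1C`, with 3-chlorophenyl, gives 9200 nM. Compound 3 `CCOC(=O)c1cc(-c2ccccc2Cl)n(-c2ccc(S(N)(=O)=O)cc2)c1C`, with 2-chlorophenyl, gives 13700 nM. Compound 3 stands clearly apart from compound 1, with a 3.3-fold higher number from compound 1 to compound 3 (0.51 log units; beyond the scatter). Compound 2 shows a similar separation, with a 2.2-fold higher number from compound 1 to compound 2 (0.34 log units; beyond the scatter). Compound 3 and compound 2 remain level, with a 1.5-fold higher number from compound 2 to compound 3 (0.17 log units; within the scatter).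

The next compound, compound 4 `CCOC(=O)c1cc(-c2ccc(C)cc2)n(-c2ccc(S(N)(=O)=O)cc2)c1C`, carries 4-methylphenyl in place of 2-chlorophenyl on an aromatic carbon, next to the ring nitrogen: 4-methylphenyl in place of 2-chlorophenyl on an aromatic carbon. Among the compounds with values here, no measured step exchanges chlorine for methyl, so the evidence is indirect. The most relevant comparison is compound 1, whose 4-chlorophenyl name matches the numbering of the entering group and which gives 4200 nM. Its step to compound 3 was modest, with a 3.3-fold higher number from compound 1 to compound 3 (0.51 log units; beyond the scatter). A modest step of similar size is therefore expected in this assay, in the opposite direction, toward a lower number. The expected change is a 2.7-fold lower number from compound 3 to compound 4 (0.44 log units; beyond the scatter). For compound 4 the estimate is 5000 nM, with an expected range from 2000 nM to 12000 nM.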

Compound 4, solubility: 1300 nM
The estimate for compound 4 lay 3.8-fold (0.59 log units) above the measured number; measured number outside the range, below it.
By their numbers in this assay, from the lowest: compound 4; then compound 1; then compounds 2 and 3 (each within the scatter of the next).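

In this assay, within the data shown here, the earlier compounds showed only what moving the chlorine around the phenyl ring does, whereas compound 4 gives the first direct exchange of the substituent itself, with a 3.2-fold lower number from compound 1 to compound 4 (0.51 log units; beyond the scatter) for methyl in place of chloro. That step matches in size the one between the two chlorine isomers, a 3.3-fold higher number from compound 1 to compound 3 (0.51 log units; beyond the scatter), so the exchange of group at this position, next to the ring nitrogen, counts for as much here as the place of the chlorine. The steps from the other isomers are accordingly wider, with a 7.1-fold lower number from compound 2 to compound 4 (0.85 log units; beyond the scatter) and, the only large step in the set, an 11-fold lower number from compound 3 to compound 4 (1.02 log units; beyond the scatter), and nothing shown explains why the methyl compound reads lowest.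

The compounds shown leave open whether 2-methylphenyl and 3-methylphenyl would climb in the same order as their chlorine counterparts, so the effect of place is known for chlorine alone. They also leave open how this position would respond to a phenyl ring carrying a methoxy group, an amine or a carboxylic acid.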